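The compounds below may be only part of what the source reports. "The series", "measured", "known", "first", "only" and "open" are said of these compounds alone.

Measured so far:
compound 1, `C=C(Br)C(=O)Nc1ccc(/C=C2\SC(=O)N(Cc3ccc(C)cc3)C2=O)cc1`: 8900 nM
compound 2, `C=C(Br)C(=O)Nc1ccc(/C=C2\SC(=O)N(Cc3ccc(Cl)cc3)C2=O)cc1`: 2300 nM
compound 3, `Nc1ccc(/C=C2\SC(=O)N(Cc3ccc(Cl)cc3)C2=O)cc1`: 77000 nM

All three were tested in a functional assay on HeLa cells (Homo sapiens) for cytotoxicity, read by cell counting, with a stated time of 4 days; on this read-out higher numbers stand for weaker inhibition and lower numbers for stronger inhibition. Compound 2 and compound 1 differ in a single spot, (methyl in place of chloro on an aromatic carbon), and that change gave a 3.9-fold higher number from compound 2 to compound 1 (0.59 log units; beyond the scatter). Compound 3 differs from compound 2 in its core: hydrogen in place of (1-bromoethenyl)carbonyl on a nitrogen on an aromatic ring, a change that gave a 33-fold higher number from compound 2 to compound 3 (1.52 log units; beyond the scatter), which leaves compound 3 with the highest number of the three.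

Compound 4, `Cc1ccc(CN2C(=O)S/C(=C\c3ccc(N)cc3)C2=O)cc1`, has not yet been measured. It carries, relative to compound 3, the same change that compound 1 carries relative to compound 2: methyl in place of chloro on an aromatic carbon. For the measured compounds named here, the place of the change is described in the same words for both pairs, so the earlier step is the only guide available. Because a 3.9-fold higher number from compound 2 to compound 1 (0.59 log units; beyond the scatter) weakened inhibition on the other core, a step of similar size is expected here as well, a 3.2-fold higher number from compound 3 to compound 4 (0.51 log units; beyond the scatter). Compound 3 already gives 77000 nM in this assay. Compound 4 is therefore expected to reach only about 250000 nM in this assay, with a likely range from 80000 nM to 800000 nM, and there is a fair chance that only a limit is reported.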

Compound 4, half-maximal inhibitory concentration: > 250000 nM
Compound 4 ended at the assay's limit; the forecaster's own chance of this, stated with the estimate: 35%; the middle value sits exactly at the limit.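

In this assay compound 4 gives > 250000 nM, which is a limit of the assay and not a number. Going by these compounds, putting methyl in place of chloro again moves the number up, an at least 3.2-fold higher number from compound 3 to compound 4 (0.51 log units; beyond the scatter), so the direction carries over to the second core, but the size of the step there stays unknown: the same change on two cores in this assay, a 3.9-fold higher number (0.59 log units; beyond the scatter) from compound 2 to compound 1 and an at least 3.2-fold higher number (0.51 log units; beyond the scatter) from compound 3 to compound 4; the limit leaves it open whether they differ. Likewise, hydrogen in place of (1-bromoethenyl)carbonyl on the nitrogen gives an at least 28-fold higher number from compound 1 to compound 4 (1.44 log units; beyond the scatter), so this large loss of inhibition appears with methyl as well as with chloro, again without showing whether the two steps match: the same change on two cores in this assay, a 33-fold higher number (1.52 log units; beyond the scatter) from compound 2 to compound 3 and an at least 28-fold higher number (1.44 log units; beyond the scatter) from compound 1 to compound 4; the limit leaves it open whether they differ.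

The compounds shown leave open how other groups on the same aromatic carbon, such as fluoro, methoxy or trifluoromethyl, would compare with chloro and methyl on either core. They also leave open whether a different group on the nitrogen, such as acetyl or chloroacetyl, would give numbers closer to those of compound 1 and compound 2 or to those of compound 3 and compound 4.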